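Moving the methoxy group on an arylpiperazine amide

The compounds below may be only part of what the source reports. "The series", "measured", "known", "first", "only" and "open" are said of these compounds alone.

Compound 1 `CC1(c2ccccc2)CC(=O)N(CC(=O)N2CCOCC2)C1=O`: 300 mg/kg
Compound 2 `CC1(c2ccccc2)CC(=O)N(CC(=O)N2CCN(c3cccc(Cl)c3)CC2)C1=O`: 300 mg/kg
Compound 3 `COc1cccc(N2CCN(C(=O)CN3C(=O)CC(C)(c4ccccc4)C3=O)CC2)c1`: "not active" (no number reported)

Of the compounds shown here, three sharing the same imide core have been tested in a functional assay on the whole organism (strain CD-1) with Mus musculus as the target, in the maximal electroshock model, with a stated time of 0.5 h; on this read-out higher numbers stand for an effect only at larger amounts of compound and lower numbers for an effect already at smaller amounts. Compound 2 stands level with compound 1 at the digits given, the two differing by no more than the scatter of repeated measurements, so no order can be read between them. Among the compounds with values here, compound 3 is recorded as "not active" (no number reported) in this assay, with no number attached, and therefore gives no step that can be sized.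

Compound 4 `COc1ccccc1N1CCN(C(=O)CN2C(=O)CC(C)(c3ccccc3)C2=O)CC1` has not been measured. It differs from compound 2 by 2-methoxyphenyl in place of 3-chlorophenyl on an amine nitrogen in a ring. Within the data shown here, no step between measured compounds bears on this change, and compound 3 shows that a methoxyphenyl ring on the amine nitrogen can go with no recorded activity. Compound 4 is therefore expected to lie close to compound 2, with a step of no change at the digits printed from compound 2 to compound 4 (within the scatter) in this assay at most within the scatter, or to show no activity at all. The estimate for compound 4 is 300 mg/kg, in the range 100 mg/kg to 600 mg/kg.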

Compound 4, minimum effective dose: 100 mg/kg
The estimate for compound 4 lay 3.0-fold (0.48 log units) above the measured number, and the stated range covers the measured number.
By their numbers in this assay, from the lowest: compound 4; then compounds 1 and 2 (each within the scatter of the next).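

In this assay, within the data shown here, the change from 3-chlorophenyl to 2-methoxyphenyl on the ring amine nitrogen gives a 3.0-fold lower number from compound 2 to compound 4 (0.48 log units; beyond the scatter) as a modest step beyond the scatter, the first sized step in this set, and it shows that the aryl group at this place can shift the dose. A methoxyphenyl ring here is also not tied to a loss of effect, since compound 4 carries a number while compound 3 is recorded as "not active" (no number reported) and its steps cannot be read. Nothing at hand explains why the number moved.

Going by these compounds, it remains open whether a pyridine ring or a benzyl group on this nitrogen would go lower still. On these data alone, it is also open whether 2-methoxyphenyl would give a similar step with a longer chain joining the amide to the shared core.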